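Thiophene in place of methoxybenzyl on the core of compound 1

This account rests on a few compounds, and the source may have more. Where it says the series, first, only, none or still open, it means among the compounds named here.

Among the measured compounds shown here, compound 1 `C=C(Br)C(=O)Nc1cccc(-c2cn3nc(Cc4cccc(OC)c4)sc3n2)c1` gives 2000 nM in a functional assay on L1210 cells (Mus musculus) for inhibition, read by cell counting, with a stated time of 2 days (on this read-out higher numbers stand for weaker inhibition and lower numbers for stronger inhibition), the lower of the two numbers so far. Compound 2 `COc1cccc(Cc2nn3cc(-c4cccc(N)c4)nc3s2)c1` gives 21000 nM, and the step of an 11-fold higher number from compound 1 to compound 2 (1.02 log units; beyond the scatter) follows hydrogen replacing the (1-bromoethenyl)carbonyl on the ring nitrogen. Compound 3 `C=C(Br)C(=O)Nc1cccc(-c2cn3nc(-c4cccs4)sc3n2)c1` carries thiophen-2-yl in place of 3-methoxybenzyl on an aromatic carbon. For the measured compounds named here, no measured step touches this position, so the change has no precedent here, and the only anchor is compound 1 at 2000 nM. The expected step is a 1.5-fold higher number from compound 1 to compound 3 (0.18 log units; within the scatter), nothing beyond the scatter. Compound 3 is therefore estimated at 3000 nM, within 800 nM to 12000 nM.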

Compound 3, half-maximal inhibitory concentration: 170 nM
Compound 3: the middle estimate sits 18-fold (1.25 log units) above what was measured; the measured number lies below the stated range.
By their numbers in this assay, from the lowest: compound 3; then compound 1; then compound 2.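

In this assay, this position on the shared core strongly affects the read-out: thiophen-2-yl in place of 3-methoxybenzyl gives a 12-fold lower number from compound 1 to compound 3 (1.07 log units; beyond the scatter). The (1-bromoethenyl)carbonyl amide is common to both compounds, so this step comes from the exchange at the aromatic carbon alone. Nothing available explains the size or direction of the step.

A single exchange cannot separate the role of the thiophene ring from that of the benzyl methylene or the methoxy group. Open too, from the compounds shown here alone, is whether phenyl or furan-2-yl at this position would track with thiophen-2-yl.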